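Three limits and one open substitution

The source may report more compounds than this note shows. Statements on the series, on what has been measured and on what is new or still open speak of the compounds shown alone.

Values from a functional assay on L02 cells (Homo sapiens) for inhibition, read by Griess assay, with stated times of 1 h and 24 h (on this read-out lower numbers stand for stronger inhibition and higher numbers for weaker inhibition), follow, each a limit and not a number:
Compound 1 `CNc1nc(/C=C/c2cc(OC)c(OC)c(OC)c2)nc2ccsc12` gives > 1000000 nM as a limit
Compound 2 `COc1cc(/C=C/c2nc(NCc3ccccc3Cl)c3sccc3n2)cc(OC)c1OC` gives > 1000000 nM as a limit
Compound 3 `COc1cc(/C=C/c2nc(OCc3ccccc3)c3sccc3n2)cc(OC)c1OC` gives > 1000000 nM as a limit

Compound 3 therefore has no exact position on the scale: its > 1000000 nM is a limit. The rest of the set offers no firmer reference, with the limit of > 1000000 nM in this assay, at which 3 of the 3 values shown sit, and no exact value among them.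

Compound 4 (`COc1cc(/C=C/c2nc(NC(C)C)c3sccc3n2)cc(OC)c1OC`) differs from compound 3 by one substitution (isopropylamino in place of benzyloxy on an aromatic carbon), on an aromatic carbon. All three measured steps bear on this, but none has a size. Compound 1 has methylamino at that place, and exchanging it for benzyloxy gives a step that the two limits leave unreadable from compound 1 to compound 3 as its result. Compound 2 has (2-chlorobenzyl)amino there, and the same exchange gives a step that the two limits leave unreadable from compound 2 to compound 3 as its result. Between the two amino groups lies a step that the two limits leave unreadable from compound 1 to compound 2 in the same read-out.

No step size can be carried over, so no direction is expected in this assay and compound 4 will most likely stay at the same limit. The expected result is a number no higher from compound 3 to compound 4 (the limit leaves the size open) as an estimate only. For compound 4 the estimated value is 1000000 nM with an expected range from 300000 nM to 2000000 nM as its span.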

Compound 4, half-maximal inhibitory concentration: > 1000000 nM
Compound 4 gave a limit, no number; the forecaster's own chance of this, stated with the estimate: 85%; the middle value lies on the limit itself.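

No step from compound 1, compound 2 or compound 3 to compound 4 can be read in this assay, because each value is a limit and not a number: the limit of > 1000000 nM in this assay, at which 4 of the 4 values shown sit.

The compounds shown leave open how strongly any of them inhibits in this assay, and whether exchanging the group on the aromatic carbon changes that at all.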